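The source may report more compounds than this note shows. Statements on the series, on what has been measured and on what is new or still open speak of the compounds shown alone.

Measured compounds in a functional assay on isolated protein for inhibition of Glucose-dependent insulinotropic receptor (Rattus norvegicus), read by HTRF and cAMP accumulation; on this read-out lower numbers stand for an effect already at smaller amounts and higher numbers for an effect only at larger amounts of compound:

Compound 1, `Cc1nc(S(C)(=O)=O)ccc1Oc1ncnc(OC2CCN(C(=O)SC(C)C)CC2)c1F`, gives 41.3 nM.
Compound 2, `Cc1nc(S(C)(=O)=O)ccc1Oc1ncnc(OC2CCN(C(=O)SC3(C)CC3)CC2)c1F`, gives 166 nM.
Compound 3, `Cc1nc(S(C)(=O)=O)ccc1Oc1ncnc(OC2CCN(C(=O)C3(F)CCC3)CC2)c1F`, gives 123 nM.

Among these three numbers compound 3 stands second highest. Its nearest neighbour is compound 2, and the pair differs only as a 1.3-fold lower number from compound 2 to compound 3 (0.13 log units; within the scatter), which stays within the scatter. Its furthest neighbour is compound 1, separated by a 3.0-fold higher number from compound 1 to compound 3 (0.47 log units; beyond the scatter).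

Compound 4, `Cc1nc(S(C)(=O)=O)ccc1Oc1ncnc(OC2CCN(C(=O)c3nc(C(C)(C)F)no3)CC2)c1F`, differs from compound 3 in one place: a group of 9 heavy atoms (5 carbon, 2 nitrogen, 1 oxygen, 1 fluorine; one five-membered aromatic ring with 3 hetero atoms) in place of a group of 5 heavy atoms (4 carbon, 1 fluorine; one four-membered non-aromatic ring of carbon only), on a carbonyl carbon. The measured steps that touch the same carbonyl carbon are a 3.0-fold higher number from compound 1 to compound 3 (0.47 log units; beyond the scatter) and a 1.3-fold lower number from compound 2 to compound 3 (0.13 log units; within the scatter); the first is modest and beyond the scatter, the second within it. Both compare small saturated or chain groups with one another. Among the compounds with values here, no measured step introduces a five-membered aromatic ring with hetero atoms at this carbonyl carbon, so the data give no direct guide to the size or direction of the new step. On that basis a small change, perhaps none beyond the scatter, is expected for compound 4 in this assay, with a wide range: a 1.2-fold higher number from compound 3 to compound 4 (0.09 log units; within the scatter).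

The estimate for compound 4 in this assay is therefore 150 nM, expected to fall between 45 nM and 500 nM.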

Compound 4, half-maximal effective concentration: 606 nM
Beside the measured number, compound 4's estimate is 4.0-fold (0.61 log units) below it, outside the stated range (above it).
By their numbers in this assay, from the lowest: compound 1; then compounds 3 and 2 (each within the scatter of the next); then compound 4.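

In this assay, within the data shown here, the earlier steps on the carbonyl carbon compared only small saturated or chain groups, and the group bearing a five-membered aromatic ring with 3 hetero atoms is the first entry of a different kind; it shows that this position does respond to such a change, and upward, with a 4.9-fold higher number from compound 3 to compound 4 (0.69 log units; beyond the scatter) and a 3.7-fold higher number from compound 2 to compound 4 (0.56 log units; beyond the scatter). Measured against the isopropyl group on a sulfur, the same replacement gives a 15-fold higher number from compound 1 to compound 4 (1.17 log units; beyond the scatter), which is large, whereas the steps among the first three compounds were modest or within the scatter, so compound 4 has the highest number of the set, beyond the scatter of every other compound. Nothing shown here accounts for this rise in the number.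

The compounds shown leave open whether the rise goes with the aromatic ring itself or with the fluorinated group it carries, as no pair here separates the two. A phenyl ring on the same carbonyl carbon, or the same five-membered ring carrying a plain methyl group, would bear on that question.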